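Dropping the fluoro from a bromo-substituted benzyl piperazine

A few compounds are considered here, and "the series" means these few. Any claim that something is new, unique, unknown or untested is made for them only; others in the source may bear on it.

Compound 1 `CCCn1c(=O)[nH]c2nc(-c3ccc(S(=O)(=O)N4CCN(Cc5cccc(C)c5)CC4)cc3)[nH]c2c1=O`: 0.397 nM
Compound 2 `CCCn1c(=O)[nH]c2nc(-c3ccc(S(=O)(=O)N4CCN(Cc5cccc(Br)c5)CC4)cc3)[nH]c2c1=O`: 0.148 nM
Compound 3 `CCCn1c(=O)[nH]c2nc(-c3ccc(S(=O)(=O)N4CCN(Cc5ccc(Br)c(F)c5)CC4)cc3)[nH]c2c1=O`: 0.473 nM

In an assay on CHO cells for displacement of a labelled ligand from adenosine receptor A2b (Homo sapiens), read by scintillation counting, with a stated time of 75 min, in the presence of a further agent that is not named here (on this read-out higher numbers stand for weaker inhibition and lower numbers for stronger inhibition), compound 3 gives the highest of the three numbers, close to compound 1 but separated from compound 2 by a 3.2-fold higher number from compound 2 to compound 3 (0.50 log units; beyond the scatter). Compound 4 `CCCn1c(=O)[nH]c2nc(-c3ccc(S(=O)(=O)N4CCN(Cc5ccc(Br)cc5)CC4)cc3)[nH]c2c1=O` differs from compound 3 by hydrogen in place of fluoro on an aromatic carbon, on an aromatic carbon ortho to a bromo group. Among the measured compounds shown here, no measured step removes a fluoro alone; the nearest guide is a 3.2-fold higher number from compound 2 to compound 3 (0.50 log units; beyond the scatter), which bundles a shift of the bromo with the entry of the fluoro, and a 2.7-fold lower number from compound 1 to compound 2 (0.43 log units; beyond the scatter), which concerns the bromo only. The fluoro's own share is therefore uncertain, and only a small step, if any, is expected: a 1.4-fold lower number from compound 3 to compound 4 (0.13 log units; within the scatter). Compound 4 is estimated at 0.35 nM, between 0.12 nM and 1 nM.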

Compound 4, inhibition constant: 0.153 nM
Compound 4: the middle estimate sits 2.3-fold (0.36 log units) above what was measured; low and high end bracket the measured number.
By their numbers in this assay, from the lowest: compounds 2 and 4 (each within the scatter of the next); then compounds 1 and 3 (each within the scatter of the next).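

In this assay, among the compounds shown here, taking away the single fluoro ortho to a bromo group is a step of its own (a 3.1-fold lower number from compound 3 to compound 4 (0.49 log units; beyond the scatter)), which the earlier steps, bundled with a shift of the bromo, could not isolate. The 4-bromophenyl and 3-bromophenyl groups do not separate (a 1.0-fold higher number from compound 2 to compound 4 (0.01 log units; within the scatter)), while the 4-bromophenyl group stands clear of 3-methylphenyl (a 2.6-fold lower number from compound 1 to compound 4 (0.41 log units; beyond the scatter)). No supporting data explain the size of the fluoro step.

As far as these compounds go, whether a chloro or a methoxy group could replace the bromo on the 4-bromophenyl group and hold this number remains open. So does whether a fluoro would give a similar step on the 3-bromophenyl group.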